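The source may hold more compounds than are shown below. What is called first, only, known or untested is meant among the compounds shown, and "the series" means these compounds.

Compound 1 `CC(=O)c1ccc(NC(=O)/C=C/C(=O)N2C/C(=C\c3ccc([N+](=O)[O-])cc3)C(=O)/C(=C/c3ccc([N+](=O)[O-])cc3)C2)cc1` is the reference point of this set. In a functional assay on CCRF-CEM cells (Homo sapiens) for cytotoxicity (on this read-out lower numbers stand for stronger inhibition and higher numbers for weaker inhibition), compound 1 gives 360 nM, the lowest of the three numbers recorded, though compound 3 `COc1ccc(NC(=O)/C=C/C(=O)N2C/C(=C\c3ccccc3)C(=O)/C(=C/c3ccccc3)C2)cc1` with 510 nM lies within the scatter of it, and only compound 2 `Cc1ccc(NC(=O)/C=C/C(=O)N2C/C(=C\c3ccccc3)C(=O)/C(=C/c3ccccc3)C2)cc1` with 1100 nM sits beyond it. Among the measured compounds shown here, the one single-point step in the set, a 2.2-fold lower number from compound 2 to compound 3 (0.33 log units; beyond the scatter), concerns a methoxy in place of a methyl and does not touch an acetyl.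

Compound 4 `Cc1ccc(NC(=O)/C=C/C(=O)N2C/C(=C\c3ccc([N+](=O)[O-])cc3)C(=O)/C(=C/c3ccc([N+](=O)[O-])cc3)C2)cc1` differs from compound 1 by methyl in place of acetyl on an aromatic carbon. For the measured compounds named here, no measured pair isolates this change; compound 1 and compound 3 differ in two places, so their values are only suggestive. Compound 1 with an acetyl group and compound 2 with a methyl group stand well apart, so the number for compound 4 is expected to rise modestly, by a 1.9-fold higher number from compound 1 to compound 4 (0.29 log units; within the scatter), to an estimated 700 nM with a range from 300 nM to 1600 nM.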

Compound 4, half-maximal inhibitory concentration: 890 nM
Beside the measured number, compound 4's estimate is 1.3-fold (0.10 log units) below it, and the stated range covers the measured number.
By their numbers in this assay, from the lowest: compounds 1, 3, 4 and 2 (each within the scatter of the next, the first and the last beyond it).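

In this assay, among the compounds shown here, methyl in place of acetyl on the aromatic carbon para to a large group gives a 2.5-fold higher number from compound 1 to compound 4 (0.39 log units; beyond the scatter) as the first direct reading of this position. A change at this one place therefore moves the number beyond the scatter, though only modestly, with the lower number belonging to the acetyl compound. Nothing available accounts for this difference.

For the compounds shown here, whether the step would hold on a different version of the shared core remains open, as this single pair is its only reading. On these data alone, how an amine or a carboxylic acid would read at this position also remains open.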